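Dichlorophenyl variants of a 5-HT6 sulfonamide piperazine

A few compounds are considered here, and "the series" means these few. Any claim that something is new, unique, unknown or untested is made for them only; others in the source may bear on it.

Measured compounds:
- Compound 1 `COc1ccc(S(=O)(=O)Nc2cccc(Br)c2)cc1N1CCNCC1`: 1.26 nM
- Compound 2 `COc1ccc(S(=O)(=O)Nc2cc(Cl)cc(Cl)c2)cc1N1CCNCC1`: 0.631 nM

In an assay on isolated protein for binding affinity to 5-hydroxytryptamine receptor 6 (Homo sapiens) (on this read-out lower numbers stand for stronger inhibition and higher numbers for weaker inhibition), compound 1 gives 1.26 nM. Its only neighbour on the numbers shown is compound 2, and the step of a 2.0-fold lower number from compound 1 to compound 2 (0.30 log units; within the scatter) lies within the scatter, so the two compounds cannot be told apart on this read-out.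

Compound 3 `COc1ccc(S(=O)(=O)Nc2ccc(Cl)c(Cl)c2)cc1N1CCNCC1` has not been measured. It differs from compound 1 by 3,4-dichlorophenyl in place of 3-bromophenyl on a sulfonamide nitrogen. Within the data shown here, the one measured step that bears on this change is the one from compound 1 to compound 2, where a dichlorophenyl also replaced the 3-bromophenyl: a 2.0-fold lower number from compound 1 to compound 2 (0.30 log units; within the scatter). That step did not leave the scatter, and the two chlorines in compound 3 sit in a different arrangement than in compound 2, so nothing beyond the scatter is expected here either. The step from compound 1 to compound 3 is therefore estimated as a 1.4-fold lower number from compound 1 to compound 3 (0.15 log units; within the scatter). Compound 3 is expected to give 0.9 nM, within the range 0.3 nM to 2.5 nM.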

Compound 3, inhibition constant: 2.51 nM
Beside the measured number, compound 3's estimate is 2.8-fold (0.45 log units) below it; the measured number lies above the stated range.
By their numbers in this assay, from the lowest: compounds 2, 1 and 3 (each within the scatter of the next, the first and the last beyond it).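

With the same two chlorines on the ring, 3,4-dichlorophenyl in place of 3,5-dichlorophenyl on the sulfonamide nitrogen gives a 4.0-fold higher number from compound 2 to compound 3 (0.60 log units; beyond the scatter) in this assay and is the only step among these compounds to leave the scatter. So a dichlorophenyl group does not fix the number by itself: the arrangement of its chlorines matters here, while the step from 3-bromophenyl to 3,4-dichlorophenyl, a 2.0-fold higher number from compound 1 to compound 3 (0.30 log units; within the scatter), stays within the scatter and leaves those two compounds indistinguishable. Nothing available here explains the effect of the chlorine arrangement.

As far as these compounds go, it remains open how this position would respond to a phenyl ring carrying a single chlorine. Also open, from the compounds shown here alone, is whether a nitrile, a methyl or an amine could take the place of the chlorines and keep the number as low.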